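Swapping fluoro for methoxy on the benzyl arm

The source may report more compounds than this note shows. Statements on the series, on what has been measured and on what is new or still open speak of the compounds shown alone.

Two compounds of this series carry a measured value in a functional assay on K562 cells (Homo sapiens) for antiproliferative activity, read by MTT assay, with a stated time of 48 h; on this read-out lower numbers stand for stronger inhibition and higher numbers for weaker inhibition. Compound 1 `Cc1ccc(-c2ccc3c(c2)C(=O)C(=O)N3)cc1` reaches only the limit of > 10000 nM, which is a limit of the assay and not a number; this is the limit described in the limit of > 10000 nM in this assay, at which 1 of the 2 values shown sits. For the measured compounds named here, compound 2 `COc1ccc(-c2ccc3c(c2)C(=O)C(=O)N3Cc2ccc(F)cc2)cc1`, which carries the 4-fluorobenzyl group on the ring nitrogen, gives 560 nM in this assay, the only actual number in hand, so compound 2 stands as the sole reference point for what follows.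

Compound 3 `COc1ccc(CN2C(=O)C(=O)c3cc(-c4ccc(OC)cc4)ccc32)cc1` differs from compound 2 in one place: methoxy in place of fluoro on an aromatic carbon, turning the 4-fluorobenzyl group into a 4-methoxybenzyl group. Going by the values given here, no measured pair shows this exchange, so the step of a 1.3-fold higher number from compound 2 to compound 3 (0.10 log units; within the scatter) is expected to stay within the usual scatter, with no clear direction. On that basis compound 3 is estimated at 700 nM in this assay, with a range from 250 nM to 2000 nM.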

Compound 3, half-maximal inhibitory concentration: 30 nM
Compound 3: middle estimate off by 23-fold (1.37 log units), on the high side; the measured number lies below the stated range.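

In this assay, for the compounds shown here, the exchange of fluoro for methoxy on the benzyl arm brings a 19-fold lower number from compound 2 to compound 3 (1.27 log units; beyond the scatter) and thereby shows what the earlier compounds could not: the group on this aromatic carbon of the benzyl arm has a large bearing on the read-out, and the change from 4-fluorobenzyl to 4-methoxybenzyl moves the number well beyond the scatter. This rests on a single pair, so it describes this one exchange on this one core and is no trend across substituents. The entering methoxy counts as a hydrogen-bond acceptor and the leaving fluoro does not, but nothing shown here ties the step to that difference or gives any other cause for it.

The compounds shown leave open whether the gain belongs to methoxy itself or would also come with a hydroxyl, an ethoxy or a dimethylamino group on the same carbon. They also leave open how much of the effect depends on the benzyl arm as a whole, which a plain longer alkyl chain on the ring nitrogen would test.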